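Removing a methyl from an aryl ether on the shared core

The compounds below may be only part of what the source reports. "The series", "measured", "known", "first", "only" and "open" are said of these compounds alone.

Compound 1 `COc1ccc(C2=NO[C@]3(C2)C(=O)O[C@@H]2[C@H]3CC[C@H](C)[C@]3(O)C=CC(=O)[C@@]23C)cc1` gives 1.47 in a physicochemical assay for lipophilicity; on this read-out lower numbers stand for lower lipophilicity and higher numbers for higher lipophilicity. Compound 2 `C[C@H]1CC[C@@H]2[C@@H](OC(=O)[C@]23CC(c2ccc(O)cc2)=NO3)[C@]2(C)C(=O)C=C[C@@]12O` differs from it by hydrogen in place of methyl on an oxygen on an aromatic ring, and in this assay compound 2 gives 0.932, the step being a number 0.54 log units lower from compound 1 to compound 2 (beyond the scatter). Compound 3 `COc1ccc(C2=NO[C@]3(C2)C(=O)O[C@@H]2[C@H]3CC[C@H](C)[C@]3(O)C=CC(=O)[C@@]23C)cc1OC` differs from compound 1 by methoxy in place of hydrogen on an aromatic carbon, and in this assay compound 3 gives 1.06. Compound 4 `COc1cc(C2=NO[C@]3(C2)C(=O)O[C@@H]2[C@H]3CC[C@H](C)[C@]3(O)C=CC(=O)[C@@]23C)ccc1O` stands to compound 3 as compound 2 stands to compound 1: the difference is hydrogen in place of methyl on an oxygen on an aromatic ring, the same change at a place described in the same words, an oxygen on an aromatic ring whose other neighbour is an aromatic carbon. Resting on a number 0.54 log units lower from compound 1 to compound 2 (beyond the scatter), the step expected in this assay is a number 0.46 log units lower from compound 3 to compound 4 (beyond the scatter), taken slightly smaller to allow for the usual scatter. Compound 4 is accordingly estimated at 0.6, with the likely span running from 0.3 to 0.95.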

Compound 4, partition coefficient: 0.75
Compound 4: the middle estimate sits 0.15 log units below what was measured; measured number inside the range.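

In this assay, hydrogen in place of methyl on the aromatic ring's oxygen gives a number 0.31 log units lower from compound 3 to compound 4 (beyond the scatter), the same direction as a number 0.54 log units lower from compound 1 to compound 2 (beyond the scatter), so the change carried over between these two aryl settings on the shared core. Alongside it stand a number 0.18 log units lower from compound 2 to compound 4 (within the scatter) and a number 0.72 log units lower from compound 1 to compound 4 (beyond the scatter), which complete the set of four compounds. Two cases on a single core make no rule for other cores, and no supporting evidence bears on why the steps have the sizes they do.

The compounds shown leave open whether the step would hold for a longer chain such as ethoxy in place of methoxy. They also leave open what an amine in place of the hydroxy would give.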